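Halogen swap on the aryl piperazine: compound 3 to compound 4

The source may report more compounds than this note shows. Statements on the series, on what has been measured and on what is new or still open speak of the compounds shown alone.

Three compounds share one core and differ only in the halogenated phenyl ring on the piperazine nitrogen: compound 1 `CCCn1c(=O)[nH]c2nc(-c3ccc(S(=O)(=O)N4CCN(c5cccc(Br)c5)CC4)cc3)[nH]c2c1=O`, compound 2 `CCCn1c(=O)[nH]c2nc(-c3ccc(S(=O)(=O)N4CCN(c5cccc(F)c5)CC4)cc3)[nH]c2c1=O` and compound 3 `CCCn1c(=O)[nH]c2nc(-c3ccc(S(=O)(=O)N4CCN(c5ccccc5Cl)CC4)cc3)[nH]c2c1=O`. In an assay on CHO cells for displacement of a labelled ligand from adenosine receptor A3 (Homo sapiens), read by scintillation counting, with a stated time of 45 min, tested at 1 uM, in the presence of a further agent that is not named here (a lower number here means less inhibition, a higher number more inhibition at the concentration tested (going by the name of the read-out)), compound 1 gives 27%, compound 2 gives 44% and compound 3 gives 32%. Compound 3 stands second highest of the three: it sits close to compound 1, since a number 5 percentage points higher from compound 1 to compound 3 (within the scatter), but clearly under compound 2, since a number 12 percentage points lower from compound 2 to compound 3 (beyond the scatter). Compound 4 `CCCn1c(=O)[nH]c2nc(-c3ccc(S(=O)(=O)N4CCN(c5ccc(I)cc5)CC4)cc3)[nH]c2c1=O` is not yet measured; it differs from compound 3 in that (4-iodophenyl in place of 2-chlorophenyl on an amine nitrogen in a ring). Among the measured compounds shown here, no measured step moves a halogen to this place on the ring, so the guidance is indirect. The steps seen are a number 17 percentage points higher from compound 1 to compound 2 (beyond the scatter), a number 5 percentage points higher from compound 1 to compound 3 (within the scatter) and a number 12 percentage points lower from compound 2 to compound 3 (beyond the scatter): the fluoro compound gave the higher number, while the bromo and chloro compounds sat lower and near one another. Iodo is closest in kind to bromo, so a step of about a number 4 percentage points lower from compound 3 to compound 4 (within the scatter) is expected, at most modest, likely within the scatter. The expected value for compound 4 in this assay is therefore 28%, with a range from 12% to 45%.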

Compound 4, a percentage reported as inhibition, at one concentration (the size of the read-out at that concentration, not a potency): 36%
Compound 4: the middle estimate sits 8 percentage points below what was measured, within the range that was stated.
By their numbers in this assay, from the lowest: compounds 1, 3, 4 and 2 (each within the scatter of the next, the first and the last beyond it).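

The 4-iodophenyl group puts a different halogen at a different place on the phenyl ring, and in this assay this change gives no step beyond the scatter: a number 4 percentage points higher from compound 3 to compound 4 (within the scatter) and a number 9 percentage points higher from compound 1 to compound 4 (within the scatter) and a number 8 percentage points lower from compound 2 to compound 4 (within the scatter). Compound 4 therefore cannot be told apart from any of the three earlier compounds, even though compound 1 and compound 2 can be told apart from each other. No supporting measurement bears on this result.

Halogen and place change together in the step from compound 3 to compound 4, and the compounds shown do not separate the two. Also open, as far as these compounds go, is whether a methoxy group or a nitrile on the phenyl ring, in place of a halogen, would give a number clearly apart from these.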